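From Dihydroxyphenyl to Chlorophenyl: An Open Step

This account rests on a few compounds, and the source may have more. Where it says the series, first, only, none or still open, it means among the compounds named here.

Going by the values given here, compound 1 `Cn1cnc2c(N3CCCCC3)nc(-c3cccc(O)c3O)nc21` holds the only full number among the three values shown in an assay on cells for displacement of a labelled ligand from adenosine receptor A1 (Homo sapiens), read by scintillation counting and radioligand binding, with a stated time of 60 min, tested at 10 uM; a lower number here means less inhibition, a higher number more inhibition at the concentration tested (going by the name of the read-out): there compound 1 gives 17.2%. Compound 2 `CN1CCN(c2nc(-c3cc(Cl)ccc3Cl)nc3[nH]cnc23)CC1` stops at a limit, and in this assay compound 2 gives > 80%. Compound 3 `CN1CCN(c2nc(-c3cccc(O)c3)nc3[nH]cnc23)CC1` also stops at a limit, so in this assay compound 3 gives > 80%. Among the compounds with values here, the one measured step between them, a step that the two limits leave unreadable from compound 2 to compound 3, offers no readable size because the limit of > 80% in this assay, at which 2 of the 3 values shown sit, is where both of its ends rest.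

Compound 4 `Cn1cnc2c(N3CCCCC3)nc(-c3cccc(Cl)c3)nc21` differs from compound 1 in a single place: 3-chlorophenyl in place of 2,3-dihydroxyphenyl on an aromatic carbon. Within the data shown here, the only measured exchange of one aryl group for another is the unreadable one already named, so no measured step gives a size or a direction for this change, and the expectation must lean on compound 1 alone, whose 17.2% sits low. Compound 2 and compound 3 carry a different amine on the shared core.

Compound 4 is therefore estimated to give 40%, with a range from 5% to 85%. The step this estimate implies, a number 22.8 percentage points higher from compound 1 to compound 4 (beyond the scatter), is an expectation and nothing more.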

Compound 4, a percentage reported as inhibition, at one concentration (the size of the read-out at that concentration, not a potency): 22.4%
Compound 4: the middle estimate sits 17.6 percentage points above what was measured, within the range that was stated.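

In this assay, putting 3-chlorophenyl in place of 2,3-dihydroxyphenyl on this aromatic carbon gives a number 5.2 percentage points higher from compound 1 to compound 4 (within the scatter). Going by these compounds alone, this is the first readable size for an exchange of one aryl group for another here, and with the piperidin-1-yl group in place the read-out at this one concentration does not separate the two aryl groups, even though the hydrogen-bond donors and acceptors counted on 2,3-dihydroxyphenyl are absent from 3-chlorophenyl. Compound 2 and compound 3 each stand at a limit of the assay and not at a number, so the earlier aryl exchange between them cannot be read: the limit of > 80% in this assay, at which 2 of the 4 values shown sit.

Open, going by these compounds, is whether the same exchange would read alike on compound 2 or compound 3, which carry a different amine on a related core. Also open, on these data alone, is whether a carboxylic acid, an amine or a longer chain on the phenyl ring at this place would give a value in this assay that stands apart from those of compound 1 and compound 4.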